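Replacing the 2-cyanophenyl group of compound 1 with a methylpyridine

A few compounds are considered here, and "the series" means these few. Any claim that something is new, unique, unknown or untested is made for them only; others in the source may bear on it.

In an assay on HEK293 cells with D(4) dopamine receptor (Homo sapiens) as the target, read by FLIPR (a higher number here means that more compound is needed for the effect, a lower number that less compound is needed), three compounds have been measured:
Compound 1 `N#Cc1ccccc1N1CCN(Cc2nc3ccccc3[nH]2)CC1` gives 14.6 nM.
Compound 2 `Fc1cccnc1N1CCN(Cc2nc3ccccc3[nH]2)CC1` gives 24 nM.
Compound 3 `N#Cc1cccnc1N1CCN(Cc2nc3ccccc3[nH]2)CC1` gives 13.9 nM.

Compound 1 stands second highest of these three numbers. Its nearest neighbour is compound 3, with a 1.1-fold lower number from compound 1 to compound 3 (0.02 log units; within the scatter), and its furthest is compound 2, with a 1.6-fold higher number from compound 1 to compound 2 (0.22 log units; within the scatter); both steps lie within the scatter, as does a 1.7-fold lower number from compound 2 to compound 3 (0.24 log units; within the scatter).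

Compound 4 `Cc1cccc(N2CCN(Cc3nc4ccccc4[nH]3)CC2)n1` differs from compound 1 in one place: 6-methylpyridin-2-yl in place of 2-cyanophenyl on an amine nitrogen in a ring. Among the measured compounds shown here, the steps that bear on this change are those from compound 1 to compound 2 and from compound 1 to compound 3, where a substituted pyridinyl group took the place of the same 2-cyanophenyl group and the numbers barely moved. Neither step, however, tested a methyl group on that ring, so the present change is less well covered. The expectation for compound 4 in this assay is therefore a step of a 1.7-fold higher number from compound 1 to compound 4 (0.23 log units; within the scatter), that is nothing clearly beyond the scatter. Compound 4 is estimated at 25 nM, within a range of 8 nM to 80 nM.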

Compound 4, half-maximal effective concentration: 36.2 nM
Beside the measured number, compound 4's estimate is 1.4-fold (0.16 log units) below it; low and high end bracket the measured number.
By their numbers in this assay, from the lowest: compounds 3, 1, 2 and 4 (each within the scatter of the next, the first and the last beyond it).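

Among the compounds shown here, measured by this assay this is the first replacement of the 2-cyanophenyl group that moves the number beyond the scatter, though only modestly (a 2.5-fold higher number from compound 1 to compound 4 (0.39 log units; beyond the scatter)). The 6-methylpyridin-2-yl group also stands modestly apart from the 3-cyanopyridin-2-yl group (a 2.6-fold higher number from compound 3 to compound 4 (0.42 log units; beyond the scatter)), while it cannot be told apart from the 3-fluoropyridin-2-yl group (a 1.5-fold higher number from compound 2 to compound 4 (0.18 log units; within the scatter)). So this position does not accept every pyridine equally, although the differences remain small, and no measurement at hand explains them.

The compounds shown leave open whether the methyl group itself or its place on the pyridine ring matters, since none carries a methyl group elsewhere on that ring. Going by these compounds, how a plain pyridin-2-yl group, or a pyridine bearing a methoxy group or an amine, would compare also remains open.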